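Swapping the amide tail on a hexafluoro-carbinol naphthalene core

The source may report more compounds than this note shows. Statements on the series, on what has been measured and on what is new or still open speak of the compounds shown alone.

Measured so far:
Compound 1, `C/C=C/C(=O)Nc1c(C(O)(C(F)(F)F)C(F)(F)F)ccc2ccccc12`: 72 nM
Compound 2, `O=C(CCc1ccccc1)Nc1c(C(O)(C(F)(F)F)C(F)(F)F)ccc2ccccc12`: 1750 nM
Compound 3, `CC(C)OC(=O)Nc1c(C(O)(C(F)(F)F)C(F)(F)F)ccc2ccccc12`: 1160 nM

All three share one core and differ only in the group attached to the amide carbonyl. In an assay on LtK cells with ATP-sensitive inward rectifier potassium channel 11 (Homo sapiens) as the target (a higher number here means that more compound is needed for the effect, a lower number that less compound is needed), compound 2 sits at the highest number of the three: its nearest neighbour is compound 3, with a 1.5-fold lower number from compound 2 to compound 3 (0.18 log units; within the scatter), and its furthest is compound 1, with a 24-fold higher number from compound 1 to compound 2 (1.39 log units; beyond the scatter).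

The next compound, compound 4 `O=C(Nc1c(C(O)(C(F)(F)F)C(F)(F)F)ccc2ccccc12)c1ccc(Cl)c(Cl)c1`, keeps everything in compound 2 except the tail, with the change (3,4-dichlorophenyl in place of phenethyl on a carbonyl carbon).

Among the measured compounds shown here, two measured steps bear on this. The step from compound 1 to compound 2, a 24-fold higher number from compound 1 to compound 2 (1.39 log units; beyond the scatter), shows that this position can move the read-out a great deal. The step from compound 2 to compound 3, a 1.5-fold lower number from compound 2 to compound 3 (0.18 log units; within the scatter), shows that not every exchange at this carbonyl does so. For the measured compounds named here, compound 4 brings a ring joined directly to the carbonyl, a pattern no measured compound shows, so the expectation is a moderate move toward a lower number with wide uncertainty, namely a 2.5-fold lower number from compound 2 to compound 4 (0.40 log units; beyond the scatter).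

Compound 4 is therefore estimated at 700 nM, within a range from 150 nM to 3000 nM.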

Compound 4, half-maximal effective concentration: 194 nM
Compound 4: middle estimate off by 3.6-fold (0.56 log units), on the high side, and the stated range covers the measured number.
By their numbers in this assay, from the lowest: compound 1; then compound 4; then compounds 3 and 2 (each within the scatter of the next).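

In this assay, the tail on the carbonyl carbon can lower the number even when the tails being swapped match in heavy-atom count and each carry one six-membered aromatic ring of carbon only, as the exchange of phenethyl for 3,4-dichlorophenyl shows (a 9.0-fold lower number from compound 2 to compound 4 (0.96 log units; beyond the scatter)). Among the compounds shown here, compound 4 also stands clearly apart from the isopropoxy tail (a 6.0-fold lower number from compound 3 to compound 4 (0.78 log units; beyond the scatter)), so it is the first aromatic tail here to leave the high-number group formed by compounds 2 and 3, though the prop-1-en-1-yl tail still gives the lowest number of the four (a 2.7-fold higher number from compound 1 to compound 4 (0.43 log units; beyond the scatter)). No measurement on hand explains why these tails differ.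

This exchange both removes the chain between ring and carbonyl and adds two chlorine atoms, so the compounds shown cannot tell which of the two changes matters; a plain phenyl on the carbonyl would help separate them. Also open, on these data alone, is how the number would respond to an amine or a carboxylic acid on that ring in place of the chlorine atoms.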